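This account rests on a few compounds, and the source may have more. Where it says the series, first, only, none or still open, it means among the compounds named here.

Measured in a functional assay on A549 cells (Homo sapiens) for antiproliferative activity, read by MTT assay, with a stated time of 48 h; a lower number here means a stronger inhibitor, a higher number a weaker inhibitor:
- compound 1 `Cc1cc2nc(NC(c3cn(-c4ccccc4)nc3-c3ccc([N+](=O)[O-])cc3)c3c(O)ccc4ccccc34)sc2cc1C`: 41900 nM
- compound 2 `COc1ccc2nc(NC(c3cn(-c4ccccc4)nc3-c3ccc(F)cc3)c3c(O)ccc4ccccc34)sc2c1`: 33600 nM
- compound 3 `Oc1ccc2ccccc2c1C(Nc1nc2ccc(Cl)cc2s1)c1cn(-c2ccccc2)nc1-c1ccc(F)cc1`: 32200 nM

Compound 3, at 32200 nM, lies within the scatter of both compound 1 and compound 2. Compound 4 `Oc1ccc2ccccc2c1C(Nc1nc2ccc(Cl)cc2s1)c1cn(-c2ccccc2)nc1-c1cccc(Cl)c1` has 3-chlorophenyl in place of 4-fluorophenyl on an aromatic carbon of the five-membered aromatic ring with 2 nitrogen: 3-chlorophenyl in place of 4-fluorophenyl on an aromatic carbon. Among the measured compounds shown here, no measured step isolates a change at this place. For the measured compounds named here, the only single-place step, a 1.0-fold lower number from compound 2 to compound 3 (0.02 log units; within the scatter), swaps chloro for methoxy elsewhere and stays within the scatter. No step beyond the scatter is therefore expected in this assay. The estimated change is a 1.1-fold lower number from compound 3 to compound 4 (0.03 log units; within the scatter). For compound 4 the expected value is 30000 nM, with an estimated range of 14000 nM to 55000 nM.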

Compound 4, half-maximal inhibitory concentration: 33300 nM
Beside the measured number, compound 4's estimate is 1.1-fold (0.05 log units) below it; low and high end bracket the measured number.
By their numbers in this assay, from the lowest: compounds 3, 4, 2 and 1 (each within the scatter of the next).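

In this assay, the exchange of 4-fluorophenyl for 3-chlorophenyl gives a 1.0-fold higher number from compound 3 to compound 4 (0.01 log units; within the scatter), the first step shown at this position on the five-membered aromatic ring. The exchange alters both the halogen and where it sits on the phenyl ring, and the combined change stays within the scatter, though the two parts cannot be separated. The data shown offer no explanation for this flat result.

From the compounds shown here alone, whether a non-aryl group at this position, such as an amine or a carboxylic acid, would move the number beyond the scatter remains open.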